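Swapping the End Group on an Active Side Chain

The compounds below may be only part of what the source reports. "The series", "measured", "known", "first", "only" and "open" are said of these compounds alone.

In a functional assay on HL60/MX2 cells (Homo sapiens) for antiproliferative activity, read by MTT assay, with a stated time of 48 h (a lower number here means a stronger inhibitor, a higher number a weaker inhibitor), compound 1 `CCn1c(N)c(-c2nc3ccccc3[nH]2)c2nc(C#N)c(C#N)nc21` gives > 50000 nM, which is a limit of the assay and not a number. Compound 2 `CCN(CC)CCCn1c(N)c(-c2nc3ccccc3[nH]2)c2nc(C#N)c(C#N)nc21`, which carries a 3-(diethylamino)propyl chain on the same core, gives 1820 nM. Among the compounds with values here, this is the only true number so far, so compound 2 can be ranked only against that limit.

Compound 3 `CN1CCN(CCCn2c(N)c(-c3nc4ccccc4[nH]3)c3nc(C#N)c(C#N)nc32)CC1` keeps the chain but ends it differently: 4-methylpiperazin-1-yl takes the place of diethylamino, on a saturated chain carbon, three bonds along the chain from an aromatic nitrogen (4-methylpiperazin-1-yl in place of diethylamino on a saturated chain carbon, three bonds along the chain from an aromatic nitrogen).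

Within the data shown here, only one measured step bears on this change. It is large, an at least 27-fold lower number from compound 1 to compound 2 (1.43 log units; beyond the scatter), and it shows that the side chain of compound 2 matters. Among the measured compounds shown here, it compares that chain with its absence, however, and no measured step compares one end group with another. The new end group also sits on an unchanged chain, so no step beyond the scatter is expected in this assay, and the estimated change is a 1.4-fold higher number from compound 2 to compound 3 (0.14 log units; within the scatter).

For compound 3 the expected value is 2500 nM, with an estimated range of 800 nM to 9000 nM.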

Compound 3, half-maximal inhibitory concentration: 3320 nM
Beside the measured number, compound 3's estimate is 1.3-fold (0.12 log units) below it, and the stated range covers the measured number.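

In this assay the end of the chain can be exchanged without a change beyond the scatter: with 4-methylpiperazin-1-yl in place of diethylamino, on a saturated chain carbon, three bonds along the chain from an aromatic nitrogen, the result is (a 1.8-fold higher number from compound 2 to compound 3 (0.26 log units; within the scatter)). The incoming group brings a six-membered non-aromatic ring and a second nitrogen, yet the two end groups cannot be told apart in these cells. The large gain seen with the first side chain also appears with the second (an at least 15-fold lower number from compound 1 to compound 3 (1.17 log units; beyond the scatter)), so it is not tied to diethylamino alone, although compound 1 stands at a limit of the assay and not a number, which makes the size of that gain a bound: the limit of > 50000 nM in this assay, at which 1 of the 3 values shown sits.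

A morpholin-4-yl or hydroxyl group at the end of the same propyl chain would show whether a nitrogen is needed there at all. From the compounds shown here alone, whether the chain length matters also stays open, and a 2-(4-methylpiperazin-1-yl)ethyl or a longer butyl chain carrying the same end group would address it.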